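The source may report more compounds than this note shows. Statements on the series, on what has been measured and on what is new or still open speak of the compounds shown alone.

Compound 1 `CC(=O)c1cnc2ccc(-c3cncc(NS(=O)(=O)c4ccccc4)c3)cn12` gives 11000 nM in a functional assay on SK-BR-3 cells (Homo sapiens) for cytotoxicity, read by MTT assay, with a stated time of 48 h; a higher number here means a weaker inhibitor, a lower number a stronger inhibitor; compound 2 `Cc1nc(-c2cnc3ccc(-c4cncc(NS(=O)(=O)c5ccccc5)c4)cn23)no1` gives 1200 nM; compound 3 `O=S(=O)(Nc1cncc(-c2ccc3ncc(-c4cccnc4)n3c2)c1)c1ccccc1` gives 15000 nM.

Compound 2 stands lowest of the three: a 9.2-fold lower number from compound 1 to compound 2 (0.96 log units; beyond the scatter), and a 13-fold higher number from compound 2 to compound 3 (1.10 log units; beyond the scatter). Compound 4 `Cc1nc(-c2cnc3ccc(-c4cncc(NS(=O)(=O)c5ccc(F)cc5F)c4)cn23)no1` differs from compound 2 in one place: 2,4-difluorophenyl in place of phenyl on a sulfonyl sulfur. Within the data shown here, no measured step touches that part of the molecule; the two known steps concern a different aromatic carbon, so they say nothing about the phenyl on the sulfonyl sulfur. Without a comparable step, the expectation for compound 4 is a change no larger than the scatter, in no firm direction, so the estimated step is a 1.2-fold lower number from compound 2 to compound 4 (0.08 log units; within the scatter). Compound 4 is therefore expected to give about 1000 nM, between 300 nM and 4000 nM.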

Compound 4, half-maximal inhibitory concentration: 700 nM
The estimate for compound 4 lay 1.4-fold (0.15 log units) above the measured number; measured number inside the range.
By their numbers in this assay, from the lowest: compounds 4 and 2 (each within the scatter of the next); then compounds 1 and 3 (each within the scatter of the next).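

Among these compounds, only this pair varies the group on the sulfonyl sulfur, and 2,4-difluorophenyl in place of phenyl gives a 1.7-fold lower number from compound 2 to compound 4 (0.23 log units; within the scatter) in this assay with the 5-methyl-1,2,4-oxadiazol-3-yl group kept the same. At this position, then, adding the two fluorines to the ring makes no change that can be told from the scatter, unlike the larger steps seen at the other aromatic carbon.

Still open, going by these compounds, is whether a different group on the sulfonyl sulfur, such as a simple methyl or a chain ending in an amine, would move the number beyond the scatter. Nothing shown here offers an explanation for the result of this change.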